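This account rests on a few compounds, and the source may have more. Where it says the series, first, only, none or still open, it means among the compounds named here.

Within the data shown here, in a functional assay on PC-3 cells (Homo sapiens) for antiproliferative activity, read by WST assay, with a stated time of 3 days (a lower number here means a stronger inhibitor, a higher number a weaker inhibitor), compound 1 `CCN(CC)CCCOc1c(-c2cc(OC)c(OC)c(OC)c2)oc2ccccc2c1=O` gives 13600 nM and compound 2 `CCCCCN(CCCCC)CCCOc1c(-c2cc(OC)c(OC)c(OC)c2)oc2ccccc2c1=O` gives 5800 nM, the lower of the two numbers so far. Compound 3 `CCCCCN(CCCCC)CCCCOc1c(-c2cc(OC)c(OC)c(OC)c2)oc2ccccc2c1=O` carries (dipentylamino)methyl in place of dipentylamino on a saturated chain carbon, three bonds along the chain from an oxygen on an aromatic ring. Among the measured compounds shown here, the only measured step, a 2.3-fold lower number from compound 1 to compound 2 (0.37 log units; beyond the scatter), is modest and changes the amine substituents, not the chain, so it bears only loosely on this change. No step beyond the scatter is therefore expected in this assay. For compound 3 the expected value is 5000 nM, with a range of 2200 nM to 11000 nM. The estimated step is a 1.2-fold lower number from compound 2 to compound 3 (0.06 log units; within the scatter).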

Compound 3, half-maximal inhibitory concentration: 7900 nM
Compound 3: the middle estimate sits 1.6-fold (0.20 log units) below what was measured; the measured number falls inside the stated range.
By their numbers in this assay, from the lowest: compounds 2, 3 and 1 (each within the scatter of the next, the first and the last beyond it).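

In this assay, (dipentylamino)methyl in place of dipentylamino gives a 1.4-fold higher number from compound 2 to compound 3 (0.13 log units; within the scatter), so this change on the saturated chain carbon does not separate the two compounds beyond the scatter. Against diethylamino, the same group gives a 1.7-fold lower number from compound 1 to compound 3 (0.24 log units; within the scatter), which also stays within the scatter, whereas dipentylamino alone was separated from diethylamino beyond it. No measured evidence bears on these results. Still open, as far as these compounds go, is how a cyclic amine such as piperidine or morpholine would read on this chain in this assay. From the compounds shown here alone, a longer chain carrying dipentylamino also remains open.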